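This account rests on a few compounds, and the source may have more. Where it says the series, first, only, none or still open, it means among the compounds named here.

Values in a functional assay on HeLa cells (Homo sapiens) for antiproliferative activity, read by MTT assay, with a stated time of 48 h (on this read-out higher numbers stand for weaker inhibition and lower numbers for stronger inhibition), for the series so far
- compound 1 `O=C(OCc1ccccc1)c1ccc2[nH]c(-c3cn(-c4ccccc4)nc3-c3ccc(F)cc3)nc2c1` gives 23600 nM
- compound 2 `O=C(OCc1ccccc1)c1ccc2[nH]c(-c3cn(-c4ccccc4)nc3-c3ccc(Cl)cc3)nc2c1` gives 8130 nM
- compound 3 `COc1ccc(-c2nn(-c3ccccc3)cc2-c2nc3cc(C(F)(F)F)ccc3[nH]2)cc1` gives 2760 nM

Compound 3 has the lowest number of the three, and its gaps to compound 1 and compound 2 both lie beyond the scatter. The next compound is compound 4 `COc1ccc(-c2nn(-c3ccccc3)cc2-c2nc3cc(C(=O)OCc4ccccc4)ccc3[nH]2)cc1`, not yet measured. It carries benzyloxycarbonyl in place of trifluoromethyl on an aromatic carbon.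

Within the data shown here, no measured step covers this exchange. Among the measured compounds shown here, the only measured step, a 2.9-fold lower number from compound 1 to compound 2 (0.46 log units; beyond the scatter), is modest and is chloro in place of fluoro on an aromatic carbon, so it bears only indirectly. It does show that a change elsewhere on this ester shifts the number. Compound 1 and compound 2 both carry the entering benzyloxycarbonyl, but they also differ from compound 3 at a second place. Even so, compound 3 gives 2760 nM, and the two compounds with the ester both stand higher: compound 2 gives 8130 nM and compound 1 gives 23600 nM. A modest to moderate move to a higher number (a 3.3-fold higher number from compound 3 to compound 4 (0.51 log units; beyond the scatter)) is therefore expected in this assay and is the working estimate here. Estimated for compound 4: 9000 nM (expected range 3000 nM to 27000 nM).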

Compound 4, half-maximal inhibitory concentration: 12400 nM
Compound 4: the middle estimate sits 1.4-fold (0.14 log units) below what was measured; low and high end bracket the measured number.
By their numbers in this assay, from the lowest: compound 3; then compounds 2, 4 and 1 (each within the scatter of the next, the first and the last beyond it).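

In this assay, the direct exchange at this position now has a size: with the rest of the molecule unchanged, benzyloxycarbonyl in place of trifluoromethyl gives a 4.5-fold higher number from compound 3 to compound 4 (0.65 log units; beyond the scatter) and so accounts for a real loss of inhibition. With benzyloxycarbonyl held in place, the exchanges on the other aromatic ring stay small, with a 1.5-fold higher number from compound 2 to compound 4 (0.18 log units; within the scatter) and a 1.9-fold lower number from compound 1 to compound 4 (0.28 log units; within the scatter), so methoxy is not separated from either chloro or fluoro on this read-out. No measured property is available to explain these steps.

Only trifluoromethyl and benzyloxycarbonyl are shown on this aromatic carbon, so it remains open whether the higher number belongs to the ester link or to its benzyl part. A carboxylic acid or an amine at the same place would help separate the two.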